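The compounds below may be only part of what the source reports. "The series", "measured", "known", "first", "only" and "open" are said of these compounds alone.

Measured so far in a physicochemical assay for lipophilicity, at pH 7.4; on this read-out higher numbers stand for higher lipophilicity and lower numbers for lower lipophilicity:
- compound 1 `CN(Cc1ccc2nccn2c1)c1nnc(-c2ccc(C3CC3)cc2)o1` gives 3.5
- compound 2 `CN(Cc1ccc2nccn2c1)c1nnc(-c2ccc(-c3ccccc3F)cc2)o1` gives 4.4
- compound 3 `Cc1nn(C)c(C)c1-c1ccc(-c2nnc(N(C)Cc3ccc4nccn4c3)o2)cc1` gives 3.1

Compound 3 carries the lowest of the three numbers in this assay. Its nearest neighbour is compound 1, with the step of a number 0.40 log units lower from compound 1 to compound 3 (beyond the scatter); its furthest is compound 2, with the step of a number 1.30 log units lower from compound 2 to compound 3 (beyond the scatter). Going by the values given here, the only other comparison available, a number 0.90 log units higher from compound 1 to compound 2 (beyond the scatter), concerns the same terminal position as those two steps.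

Compound 4 `COc1cc(-c2c(C)nn(C)c2C)ccc1-c1nnc(N(C)Cc2ccc3nccn3c2)o1` keeps the 1,3,5-trimethyl-1H-pyrazol-4-yl group of compound 3 and differs by methoxy in place of hydrogen on an aromatic carbon; the new group sits on an aromatic carbon of a six-membered aromatic ring of carbon only, ortho to a large group and meta to the 1,3,5-trimethyl-1H-pyrazol-4-yl group.

None of the three measured steps involves a methoxy group or this ring position; all three swap the whole terminal group and are therefore only loosely informative here. Among the compounds with values here, with no direct precedent, the step from compound 3 to compound 4 in this assay is expected to be small, at most at the edge of the scatter, and if anything slightly upward: a number 0.10 log units higher from compound 3 to compound 4 (within the scatter). For compound 4 the estimate in this assay is 3.2, with a range from 2.8 to 3.6.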

Compound 4, distribution coefficient: 2.9
Compound 4: the middle estimate sits 0.30 log units above what was measured; measured number inside the range.
By their numbers in this assay, from the lowest: compounds 4 and 3 (each within the scatter of the next); then compound 1; then compound 2.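

In this assay, going by these compounds alone, the earlier steps all exchange the whole terminal group, and the largest of them is a number 1.30 log units lower from compound 2 to compound 3 (beyond the scatter); they say nothing about substitution on the six-membered aromatic ring that carries that group. Methoxy in place of hydrogen on an aromatic carbon of this ring, ortho to a large group and meta to the 1,3,5-trimethyl-1H-pyrazol-4-yl group, gives a number 0.20 log units lower from compound 3 to compound 4 (within the scatter), so this read-out does not separate the two compounds. Nothing available bears on why this change at this position behaves as it does.

Methoxy is seen here with only the 1,3,5-trimethyl-1H-pyrazol-4-yl terminal group, and it remains open whether the same change on compound 1 or compound 2, with their cyclopropyl and 2-fluorophenyl groups, would also stay within the scatter. Also open, from the compounds shown here alone, is what an amine, a carboxylic acid or a longer ether chain at this same position would do to the number in this assay.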